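Chloro on the sulfonyl phenyl: a small series

The compounds below may be only part of what the source reports. "The series", "measured", "known", "first", "only" and "open" are said of these compounds alone.

Two compounds share one core and differ only at a nitrogen substituent. Compound 1 `CN(C(=O)c1ccccc1)c1ccc2[nH]c(-c3n[nH]c4ccccc34)cc2n1` carries a benzoyl group there; in a functional assay on A549 cells (Homo sapiens) for antiproliferative activity, read by MTT assay, with a stated time of 72 h (on this read-out higher numbers stand for weaker inhibition and lower numbers for stronger inhibition), compound 1 gives 13800 nM. Compound 2 `CN(c1ccc2[nH]c(-c3n[nH]c4ccccc34)cc2n1)S(=O)(=O)c1ccccc1` carries a phenylsulfonyl group instead, and in this assay compound 2 gives 14000 nM. Among the compounds with values here, the only measured step, a 1.0-fold higher number from compound 1 to compound 2 (0.01 log units; within the scatter), shows that the two groups behave alike here. Compound 2 thus holds the higher of the two numbers, but by a margin that means nothing.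

Compound 3 `CN(c1ccc2[nH]c(-c3n[nH]c4ccccc34)cc2n1)S(=O)(=O)c1ccc(Cl)cc1` is the next member. It differs from compound 2 by chloro in place of hydrogen on an aromatic carbon. Within the data shown here, no measured step touches this change: the step from compound 1 to compound 2 alters the linking group, not the ring, so it offers no guidance on a chloro substituent. The data therefore give no reason to expect a step beyond the scatter, and the estimate is anchored on compound 2 with a wide range. For compound 3 in this assay a value of 10000 nM is estimated, between 3500 nM and 30000 nM, which amounts to an expected step of a 1.4-fold lower number from compound 2 to compound 3 (0.15 log units; within the scatter).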

Compound 3, half-maximal inhibitory concentration: 18200 nM
The estimate for compound 3 lay 1.8-fold (0.26 log units) below the measured number; low and high end bracket the measured number.
By their numbers in this assay, from the lowest: compounds 1, 2 and 3 (each within the scatter of the next).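

In this assay, within the data shown here, the replacement of hydrogen by chloro on an aromatic carbon of the phenylsulfonyl ring, para to a large group, gives a 1.3-fold higher number from compound 2 to compound 3 (0.11 log units; within the scatter) and so provides the first reading on the ring itself rather than on the linking group: at this place, chloro cannot be told apart from hydrogen. The comparison with the benzoyl compound gives a 1.3-fold higher number from compound 1 to compound 3 (0.12 log units; within the scatter) and shows that exchanging benzoyl for (4-chlorophenyl)sulfonyl also yields a number that cannot be separated from the starting one, so the three compounds form one flat group with no meaningful order among them. Nothing available bears on why these numbers lie so close together.

On these data alone, one substituent at one place on the ring says little about the ring as a whole, so it remains open whether an amine, a methoxy group or a carboxylic acid in place of chloro would give a step beyond the scatter. As far as these compounds go, it is equally open whether chloro elsewhere on this ring, or on the phenyl ring of the benzoyl group, would behave as it does here.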